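Swapping ethyl for fluorophenyl on a low-toxicity amide

A few compounds are considered here, and "the series" means these few. Any claim that something is new, unique, unknown or untested is made for them only; others in the source may bear on it.

Compound 1 `COc1ccc(-c2cnc(NC(=O)c3ccc(F)cc3)n2Cc2ccccc2)cc1`: in a toxicity assay on THP-1 cells (Homo sapiens) for inhibition (on this read-out higher numbers stand for lower toxicity in this test and lower numbers for higher toxicity in this test), compound 1 gives > 100000 nM, which is a limit of the assay rather than a number.
Compound 2 `CCC(=O)Nc1ncc(-c2ccc(OC)cc2)n1C`: in this assay compound 2 gives > 100000 nM, again a limit.
Compound 3 `Cn1c(-c2ccccc2)cnc1NC(=O)c1ccccc1Cl`: in this assay compound 3 gives > 50000 nM, also a limit.

Compound 2 therefore stands only at a limit, and it is not alone there: two of the three results sit at the limit of > 100000 nM in this assay, at which 2 of the 3 values shown sit, and the third at the limit of > 50000 nM in this assay, at which 1 of the 3 values shown sits. Going by the values given here, none of the three compounds shows measurable toxicity within the tested range, and no step between measured compounds is available to show what any single change does.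

Compound 4 `COc1ccc(-c2cnc(NC(=O)c3cccc(F)c3)n2C)cc1` has not yet been measured. It differs from compound 2 in one place, (3-fluorophenyl in place of ethyl on a carbonyl carbon), so the amide now carries a ring where compound 2 carries a short chain.

Since every measured compound, with chain or with ring on the carbonyl, reached a limit, the step from compound 2 to compound 4 is expected to be none beyond the scatter, as a number no higher from compound 2 to compound 4 (the limit leaves the size open) expresses. Compound 4 is expected to come out at 100000 nM, within a range from 50000 nM to 200000 nM, most likely reported once more as a limit.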

Compound 4, half-maximal cytotoxic concentration: > 100000 nM
Compound 4: a limit, no number (the forecaster's own chance of this, stated with the estimate: 85%); the middle value lies on the limit itself.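

In this assay compound 4 gives > 100000 nM, a limit and not a number. Compound 2 also rests on a limit, so the step between compound 2 and compound 4 cannot be read. The compounds shown leave open at what concentration any of them would become toxic to these cells.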